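The source may report more compounds than this note shows. Statements on the series, on what has been measured and on what is new or still open speak of the compounds shown alone.

The measured compounds and their numbers in an assay on HEK293 cells for displacement of a labelled ligand from NPC1-like intracellular cholesterol transporter 1 (Homo sapiens) (a lower number here means a stronger inhibitor, a higher number a weaker inhibitor), are these:
compound 1 `CC(C)(C)OC(=O)NCCNC(=O)CN1CN(c2ccccc2)C2(CCN(C(=O)c3ccc(C(C)(C)C)cc3)CC2)C1=O` with 10900 nM;
compound 2 `COC(=O)CCNC(=O)CN1CN(c2ccccc2)C2(CCN(C(=O)c3ccc(C4CCCCC4)cc3)CC2)C1=O` with 12900 nM;
compound 3 `NC(=O)C1CCCN(C(=O)CN2CN(c3ccccc3)C3(CCN(C(=O)c4ccc(C5CCCCC5)cc4)CC3)C2=O)C1` with 3100 nM.

Among these three numbers compound 1 stands second highest. Its nearest neighbour is compound 2, whose number lies within the scatter of that of compound 1, so the two cannot be told apart. Compound 3 lies furthest from compound 1, beyond the scatter.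

The new compound 4 `CC(C)(C)c1ccc(C(=O)N2CCC3(CC2)C(=O)N(CC(=O)N2CCC(CCO)CC2)CN3c2ccccc2)cc1` arises from compound 1 through one change on the shared core: 4-(2-hydroxyethyl)piperidin-1-yl in place of (2-((tert-butoxycarbonyl)amino)ethyl)amino on a carbonyl carbon

Among the measured compounds shown here, one measured step bears on this. From compound 2 to compound 3 an amino group on a carbonyl carbon gave way to a piperidinyl group, and the result was a 4.2-fold lower number from compound 2 to compound 3 (0.62 log units; beyond the scatter). Compound 4 carries the same kind of exchange on the same carbonyl carbon of compound 1, an amino group leaving and a piperidinyl group entering. For the measured compounds named here, only this single step is available, and the two piperidinyl groups differ, so the expectation is tentative; still, a step downward of roughly the size seen from compound 2 to compound 3 is expected in this assay. For compound 4 the expected result is 4000 nM, in a range from 1800 nM to 9000 nM, that is, an expected step of a 2.7-fold lower number from compound 1 to compound 4 (0.44 log units; beyond the scatter).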

Compound 4, half-maximal inhibitory concentration: 2600 nM
Compound 4: middle estimate off by 1.5-fold (0.19 log units), on the high side; the measured number falls inside the stated range.
By their numbers in this assay, from the lowest: compounds 4 and 3 (each within the scatter of the next); then compounds 1 and 2 (each within the scatter of the next).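

In this assay, among the compounds shown here, the exchange of an open-chain amino group for a piperidinyl group on this carbonyl carbon now appears in two pairs of compounds, with a 4.2-fold lower number from compound 1 to compound 4 (0.62 log units; beyond the scatter) and, in the earlier pair, a 4.2-fold lower number from compound 2 to compound 3 (0.62 log units; beyond the scatter), so the lower number is no longer seen only with the substituents that compound 2 and compound 3 carry elsewhere on the shared core. The result also shows that this position accepts 4-(2-hydroxyethyl)piperidin-1-yl as well as the 3-carbamoylpiperidin-1-yl of compound 3, although the two groups differ in the substituent on the ring and in where it sits. Nothing measured here gives a reason for the lower number in either pair.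

The compounds shown leave open whether the ring alone accounts for the step or whether the substituent on it contributes, since the change in compound 4 also removes the tert-butoxycarbonyl group and replaces the whole chain. A plain piperidin-1-yl group would separate these two parts, and a piperidine carrying a carboxylic acid, an amine or a longer hydroxyalkyl chain would show how much the substituent on the ring matters.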